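This account rests on a few compounds, and the source may have more. Where it says the series, first, only, none or still open, it means among the compounds named here.

Of the compounds shown here, two have numbers so far in a functional assay on MCF7 cells (Homo sapiens) for inhibition, with a stated time of 48 h (on this read-out lower numbers stand for stronger inhibition and higher numbers for weaker inhibition), and share the same trimethoxyphenyl-free reading only as far as the shared core goes. Compound 1 `COc1cc(Sc2c(C)[nH]c3ccccc23)cc(OC)c1OC` gives 46 nM in this read-out. Compound 2 `COc1cc(Sc2c[nH]c3ccc(F)cc23)cc(OC)c1OC` gives 160 nM as the higher of the two numbers, and its gap to compound 1 lies beyond the usual scatter. Among the measured compounds shown here, these two compounds differ in more than one place, so no measured single-change step is available as a guide.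

Compound 3 `COc1cc(Sc2c[nH]c3ccc(OCCO)cc23)cc(OC)c1OC` has no number yet. It carries 2-hydroxyethoxy in place of fluoro on an aromatic carbon and is otherwise the same as compound 2. For the measured compounds named here, the entering group is the larger of the two, and the series holds no measured example of such an exchange. A moderate move toward weaker inhibition, beyond the scatter, is therefore expected, with wide uncertainty that includes no change. The expected step is a 2.2-fold higher number from compound 2 to compound 3 (0.34 log units; beyond the scatter) in that direction. In this assay the estimate for compound 3 is 350 nM with an expected range from 100 nM to 1200 nM for now.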

Compound 3, half-maximal inhibitory concentration: 95 nM
Compound 3: middle estimate off by 3.7-fold (0.57 log units), on the high side; measured number below the stated range.
By their numbers in this assay, from the lowest: compound 1; then compounds 3 and 2 (each within the scatter of the next).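

In this assay, 2-hydroxyethoxy in place of fluoro on this aromatic carbon gives a 1.7-fold lower number from compound 2 to compound 3 (0.23 log units; within the scatter), so this exchange does not separate the two compounds. Among the compounds shown here, this is the first single-change step, and it shows that this carbon, meta to a fused ring and para to a fused ring, can carry a chain of 4 heavy atoms, with 1 hydrogen-bond donor and 2 hydrogen-bond acceptors, in place of a single fluorine without a shift beyond the scatter; that finding rests on this one pair. Nothing measured on these compounds bears on why the two numbers lie so close.

Still open, from the compounds shown here alone, is how far this tolerance extends: a longer chain ending in a hydroxyl, a 2-aminoethoxy chain carrying an amine, or a chain ending in a carboxylic acid could each read differently on the same carbon. A plain methoxy group in this place would also help show whether the terminal hydroxyl of the 2-hydroxyethoxy chain matters at all, or whether the ether oxygen alone is enough to give a similar number.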